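The source may hold more compounds than are shown below. What is called first, only, known or untested is meant among the compounds shown, and "the series" means these compounds.

Working notes on the series. Compound 1 `CS(=O)(=O)NC1CCC(CN2CCN(c3cc(=O)c4cc(C(F)(F)F)cc([N+](=O)[O-])c4s3)CC2)CC1` and compound 2 `C=CC(=O)OC1CCC(CN2CCN(c3cc(=O)c4cc(C(F)(F)F)cc([N+](=O)[O-])c4s3)CC2)CC1` share one core and differ in a single group on a saturated ring carbon. In an ADME assay on Vero cells (Chlorocebus sabaeus) for cytotoxicity, read by MTT assay, with a stated time of 48 h (on this read-out lower numbers stand for stronger inhibition and higher numbers for weaker inhibition), compound 1 gives 48.5 ug/mL. For compound 2 the read-out is a limit of the assay and not a number: compound 2 gives > 64 ug/mL. Going by the values given here, the one measured step, an at least 1.3-fold higher number from compound 1 to compound 2 (0.12 log units; that floor lies within the scatter), is itself only a floor, which rests on (the limit of > 64 ug/mL in this assay, at which 1 of the 2 values shown sits). On the numbers shown, compound 2 thus stands at the limit, with no finite value of its own in this assay.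

Compound 3 `O=C(OC1CCC(CN2CCN(c3cc(=O)c4cc(C(F)(F)F)cc([N+](=O)[O-])c4s3)CC2)CC1)c1ccc(F)cc1` follows from compound 2 by 4-fluorophenyl in place of vinyl on a carbonyl carbon. Among the compounds with values here, no measured step touches the carbonyl carbon, so the move from methanesulfonamido to (vinylcarbonyl)oxy is the only guide, and it is a floor lying within the scatter. In this assay the expectation for the present change is accordingly no step beyond the scatter, in either direction. The expected step is a number no higher from compound 2 to compound 3 (the limit leaves the size open). Compound 3 is estimated at 64 ug/mL, within 30 ug/mL to 130 ug/mL, with a fair chance that the assay again reports only a limit.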

Compound 3, half-maximal inhibitory concentration: > 64 ug/mL
Compound 3: only a limit was reported; the forecaster's own chance of this, stated with the estimate: 60%; the middle value sits exactly at the limit.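

The carbonyl carbon now has two groups on record, vinyl and 4-fluorophenyl, and neither gives a finite value in this assay: the limit of > 64 ug/mL in this assay, at which 2 of the 3 values shown sit.

Going by these compounds, the step between compound 2 and compound 3 cannot be read, so the size of the change from vinyl to 4-fluorophenyl on this carbonyl carbon remains unknown. Going by these compounds alone, the only readable new step is an at least 1.3-fold higher number from compound 1 to compound 3 (0.12 log units; that floor lies within the scatter), and as a floor it sets no size for this change of group.

On these data alone, whether an amine, a carboxylic acid or a longer chain on the carbonyl carbon would bring the read-out in this assay to a finite number remains open. As far as these compounds go, how far compound 2 and compound 3 each lie from compound 1 also remains open, as does any order between them.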